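A Methyl-Bearing Ring Replaces a Fluorine-Bearing One

The source may report more compounds than this note shows. Statements on the series, on what has been measured and on what is new or still open speak of the compounds shown alone.

Three measured compounds share one core and differ only in the aromatic ring attached to an amine nitrogen in a ring. In an assay on CHO cells for displacement of a labelled ligand from adenosine receptor A2b (Homo sapiens), read by scintillation counting, with a stated time of 75 min, in the presence of a further agent that is not named here (a lower number here means a stronger inhibitor, a higher number a weaker inhibitor), compound 1 `CCCn1c(=O)[nH]c2nc(-c3ccc(S(=O)(=O)N4CCN(c5ccc(F)cc5)CC4)cc3)[nH]c2c1=O` gives 0.644 nM, the second highest of the three numbers. Compound 2 `CCCn1c(=O)[nH]c2nc(-c3ccc(S(=O)(=O)N4CCN(c5ccc(Cl)cc5F)CC4)cc3)[nH]c2c1=O` gives 1.91 nM, and compound 3 `CCCn1c(=O)[nH]c2nc(-c3ccc(S(=O)(=O)N4CCN(c5ccc(Br)cc5)CC4)cc3)[nH]c2c1=O` gives 0.0835 nM. The step of a 3.0-fold higher number from compound 1 to compound 2 (0.47 log units; beyond the scatter) accompanied 4-chloro-2-fluorophenyl in place of 4-fluorophenyl, the step of a 7.7-fold lower number from compound 1 to compound 3 (0.89 log units; beyond the scatter) accompanied bromo in place of fluoro on an aromatic carbon, and between those two rings the step was a 23-fold lower number from compound 2 to compound 3 (1.36 log units; beyond the scatter).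

Compound 4 `CCCn1c(=O)[nH]c2nc(-c3ccc(S(=O)(=O)N4CCN(c5ccccc5C)CC4)cc3)[nH]c2c1=O` has not yet been measured. It differs from compound 1 as follows: 2-methylphenyl in place of 4-fluorophenyl on an amine nitrogen in a ring. Going by the values given here, the step that bears most closely on this change is the one from compound 1 to compound 2, where an extra group entered the ring and the number rose modestly; the steps to compound 3 concern a halogen swap alone and offer less guidance. A modest rise beyond the scatter is therefore expected, in the direction of a weaker inhibitor. The expected step is a 2.8-fold higher number from compound 1 to compound 4 (0.45 log units; beyond the scatter). Compound 4 is estimated to give 1.8 nM in this assay, within a range from 0.5 nM to 7 nM.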

Compound 4, inhibition constant: 0.432 nM
The estimate for compound 4 lay 4.2-fold (0.62 log units) above the measured number; measured number below the stated range.
By their numbers in this assay, from the lowest: compound 3; then compounds 4 and 1 (each within the scatter of the next); then compound 2.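

In this assay, the change to 2-methylphenyl gives a 1.5-fold lower number from compound 1 to compound 4 (0.17 log units; within the scatter), so compounds 1 and 4 cannot be told apart, and a halogen on this ring is not required to reach a number as low as that of compound 1. The other two comparisons place compound 4 clearly on either side, with a 5.2-fold higher number from compound 3 to compound 4 (0.71 log units; beyond the scatter) and a 4.4-fold lower number from compound 2 to compound 4 (0.65 log units; beyond the scatter), so 4-bromophenyl keeps its lead, while the higher number of compound 2 proves not to be a general cost of replacing 4-fluorophenyl with another substituted ring. No measurement shown here explains why these rings give these numbers.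

The change from 4-fluorophenyl to 2-methylphenyl removes a fluorine and adds a methyl at a different place on the ring, so the contribution of each part cannot be separated from these compounds alone. Plain phenyl and 4-methylphenyl would bear on that question, and 2-bromophenyl on whether the bromine of compound 3 keeps its advantage at another place on the ring; the compounds shown leave all three open.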